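This account rests on a few compounds, and the source may have more. Where it says the series, first, only, none or still open, it means among the compounds named here.

Measured in a physicochemical assay for lipophilicity, using the shake flask method, measured as octanol-water partition, at pH 7.4; a higher number here means a more lipophilic compound, a lower number a more polar compound:
- compound 1 `COc1cc(/C=C/C(=O)Nc2ccccc2)ccc1OCCCN1CCCC1` gives 1.57
- compound 2 `COc1cc(/C=C/C(=O)Nc2ccccc2)ccc1OCCCCN1CCCC1` gives 1.6
- compound 3 `COc1cc(/C=C/C(=O)Nc2ccccc2)ccc1O` gives 1.42

All three numbers sit close together. Compound 2 is separated from the others only by steps within the scatter: a number 0.03 log units higher from compound 1 to compound 2 (within the scatter) and a number 0.18 log units lower from compound 2 to compound 3 (within the scatter); the step of a number 0.15 log units lower from compound 1 to compound 3 (within the scatter) is of the same kind. So on these numbers compound 2 cannot be told apart from compound 1 or compound 3.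

Compound 4 `COc1cc(/C=C/C(=O)Nc2ccccc2)ccc1OCCCCCCCCN(C)C` is reached from compound 2 by the change (4-(dimethylamino)butyl in place of pyrrolidin-1-yl on a saturated chain carbon, four bonds along the chain from an oxygen on an aromatic ring). The measured steps that bear on it are those in which the amine-bearing chain was lengthened or removed entirely, and none of them moved this assay beyond the scatter. The change to compound 4 opens the ring and lengthens the chain by a few carbons, so the expected step of a number 0.20 log units higher from compound 2 to compound 4 (within the scatter) in this assay is small and upward at most. Compound 4 is therefore estimated at 1.8, within a range from 1.4 to 2.3.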

Compound 4, partition coefficient: 1.74
Compound 4: middle estimate off by 0.06 log units, on the high side; the measured number falls inside the stated range.
By their numbers in this assay, from the lowest: compounds 3, 1, 2 and 4 (each within the scatter of the next, the first and the last beyond it).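

In this assay, replacing the pyrrolidin-1-yl ring with the open 4-(dimethylamino)butyl group, four bonds along the chain from an oxygen on an aromatic ring, gives a number 0.14 log units higher from compound 2 to compound 4 (within the scatter) and, read from the shorter chain, a number 0.17 log units higher from compound 1 to compound 4 (within the scatter). This position has therefore now taken an opened ring and a clearly longer chain together, not just one extra chain carbon, with the read-out still staying inside the scatter. No evidence is available to explain this result.

From the compounds shown here alone, the ring opening and the chain lengthening arrive together here, so the share of each stays unknown; a dimethylamino group on the chain of compound 2 would separate them. Also open, going by these compounds, is whether a carboxylic acid in place of the amine at the chain end would shift this assay beyond the scatter.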